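Iodo substitution on the benzamido ring of compound 2

The source may report more compounds than this note shows. Statements on the series, on what has been measured and on what is new or still open speak of the compounds shown alone.

Of the compounds shown here, two carry numbers so far. Compound 1 `NC(=O)c1c(NC(=O)c2ccccc2Cl)sc2c1CCN(C(=S)Nc1c(Cl)cccc1Cl)C2` gives 4020 nM in a functional assay on MKN-74 cells (Homo sapiens) for antiproliferative activity, with a stated time of 24 h (on this read-out lower numbers stand for stronger inhibition and higher numbers for weaker inhibition), and compound 2 `NC(=O)c1c(NC(=O)c2ccccc2)sc2c1CCN(C(=S)Nc1ccccc1Cl)C2` gives 11800 nM in this assay, the highest of the two numbers; the gap to compound 1 lies beyond the usual scatter. The two differ in more than one place, so no single step can be read from them. Compound 3 `NC(=O)c1c(NC(=O)c2ccccc2I)sc2c1CCN(C(=S)Nc1ccccc1Cl)C2` has not yet been measured. It differs from compound 2 by iodo in place of hydrogen on an aromatic carbon. Within the data shown here, no measured pair isolates this change, and compound 1, with the lower number, offers no clean guide. A modest downward step is expected for this assay, a 1.8-fold lower number from compound 2 to compound 3 (0.26 log units; within the scatter), possibly no larger than the scatter. Compound 3 is estimated at 6500 nM in this assay, with a range from 2500 nM to 16000 nM.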

Compound 3, half-maximal inhibitory concentration: 17500 nM
Compound 3: the middle estimate sits 2.7-fold (0.43 log units) below what was measured; measured number outside the range, above it.
By their numbers in this assay, from the lowest: compound 1; then compounds 2 and 3 (each within the scatter of the next).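

Among these compounds, this is the first single-change step: iodo in place of hydrogen on the benzamido ring, ortho to a large group, gives a 1.5-fold higher number from compound 2 to compound 3 (0.17 log units; within the scatter) in this assay. Compounds 2 and 3 therefore cannot be separated on this read-out, so this one heavy atom at this place leaves the number within the scatter. No available data bear on what lies behind this result.

Going by these compounds, whether a different group at this place, such as an amine, a carboxylic acid or a methoxy group, would move the number beyond the scatter remains open. Also open, on these data alone, is whether iodo would give the same result on the core of compound 1, which differs from compound 2 in more than one place and so does not isolate this ring.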